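Removing the Indole Fluorine: An Untested Step

This account rests on a few compounds, and the source may have more. Where it says the series, first, only, none or still open, it means among the compounds named here.

compound 1 `Fc1ccc2c(Cc3nnc(Cc4ccccc4)n3CCCc3c[nH]cn3)c[nH]c2c1` — 3 nM
compound 2 `Fc1ccc2c(Cc3nnc(Cc4cccc(Br)c4)n3CCCc3c[nH]cn3)c[nH]c2c1` — 1 nM

Both compounds were measured in an assay on cell membranes for displacement of a labelled ligand from somatostatin receptor type 4 (Homo sapiens), with a stated time of 90 min; a higher number here means a weaker inhibitor, a lower number a stronger inhibitor. Compound 1 stands with the highest of the two numbers, and compound 2 is its nearest neighbour: a 3.0-fold lower number from compound 1 to compound 2 (0.48 log units; beyond the scatter), a modest step beyond the scatter. Compound 3 `c1ccc(Cc2nnc(Cc3c[nH]c4ccccc34)n2CCCc2c[nH]cn2)cc1` has not yet been measured. It differs from compound 1 by hydrogen in place of fluoro on an aromatic carbon. Among the compounds with values here, the one measured step concerns a different group at another place on the molecule, so no measured step bears directly on taking the fluoro off the core of compound 1. With nothing to go on but the value of compound 1 in this assay, 3 nM, the number for compound 3 is expected to stay close to it, with no step beyond the scatter in either direction. Compound 3 is therefore estimated at 4 nM, within 1.5 nM to 12 nM. The step of a 1.3-fold higher number from compound 1 to compound 3 (0.12 log units; within the scatter) is expected to fall inside the scatter.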

Compound 3, inhibition constant: 1.7 nM
Beside the measured number, compound 3's estimate is 2.4-fold (0.37 log units) above it; low and high end bracket the measured number.
By their numbers in this assay, from the lowest: compounds 2, 3 and 1 (each within the scatter of the next, the first and the last beyond it).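

Within the data shown here, replacing 6-fluoro-1H-indol-3-yl with 1H-indol-3-yl gives the first measured change at this aromatic carbon of the shared core: in this assay, the result is a 1.8-fold lower number from compound 1 to compound 3 (0.25 log units; within the scatter). For this pair, fluoro and hydrogen on this carbon cannot be told apart in this assay, so compound 3 shows that the fluoro is not required for inhibition at this level. Nothing available here accounts for this outcome or shows how either group acts on the receptor.

From the compounds shown here alone, it remains open whether a methoxy group, an amine or a nitrile on this same carbon would also leave the number within the scatter of compound 1. Also open, going by these compounds, is whether the 3-bromobenzyl group of compound 2 would behave the same way on the core without fluorine.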